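The source may report more compounds than this note shows. Statements on the series, on what has been measured and on what is new or still open speak of the compounds shown alone.

Measured compounds:

Compound 1, `COc1ccc(Nc2ncc(C(F)(F)F)c(N3Cc4cccc(N(C)S(C)(=O)=O)c4C3)n2)cc1C(F)(F)F`: in a functional assay on U-87MG ATCC cells for antiproliferative activity against U-87 MG (Homo sapiens), read by spectrophotometry, with a stated time of 2 days (a lower number here means a stronger inhibitor of growth, a higher number a weaker inhibitor of growth), compound 1 gives 29400 nM.

Compound 2, `CN(c1cccc2c1CN(c1nc(Nc3cccc(C(F)(F)F)c3)ncc1C(F)(F)F)C2)S(C)(=O)=O`: for compound 2 the result in this assay is only a limit, > 30000 nM, not a number.

Among the measured compounds shown here, compound 1 is the only compound here with an actual number; the other result is a limit (the limit of > 30000 nM in this assay, at which 1 of the 2 values shown sits). Compound 2 differs from compound 1 by hydrogen in place of methoxy on an aromatic carbon, and the step of an at least 1.0-fold higher number from compound 1 to compound 2 (0.00 log units; that floor lies within the scatter) shows only a floor that lies within the scatter, so the two are not distinguishable.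

Compound 3, `Cc1cc(F)ccc1Nc1ncc(C(F)(F)F)c(N2Cc3cccc(N(C)S(C)(=O)=O)c3C2)n1`, is not yet measured. It differs from compound 1 as follows: 4-fluoro-2-methylphenyl in place of 4-methoxy-3-(trifluoromethyl)phenyl on a nitrogen on an aromatic ring. For the measured compounds named here, this is a larger change than the one seen between compound 1 and compound 2, and no measured step involves a 4-fluoro-2-methylphenyl group, so the only guide is that both measured compounds sit at the weak end of the range. The expected step of a 1.0-fold higher number from compound 1 to compound 3 (0.01 log units; within the scatter) is therefore none beyond the scatter, with a real chance that only a limit is reported. For compound 3 the estimate in this assay is 30000 nM, within 10000 nM to 90000 nM.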

Compound 3, concentration for 50% growth inhibition: > 30000 nM
Compound 3: only a limit was reported; the forecaster's own chance of this, stated with the estimate: 55%; the middle value lies on the limit itself.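

Replacing the 4-methoxy-3-(trifluoromethyl)phenyl on the nitrogen with the smaller 4-fluoro-2-methylphenyl, a much larger change than the loss of methoxy alone, still gives no sign of a stronger inhibitor of growth in this assay. The change reads as an at least 1.0-fold higher number from compound 1 to compound 3 (0.00 log units; that floor lies within the scatter), so compound 3 cannot be told apart from compound 1, while the step between compound 2 and compound 3 cannot be read at all, as both results are limits. Three different aromatic groups on this nitrogen have now left the series at the weak end, and most of the results sit at the same ceiling: the limit of > 30000 nM in this assay, at which 2 of the 3 values shown sit.

Going by these compounds, how far compound 2 and compound 3 lie beyond that limit remains unknown, so any real differences among the three compounds stay hidden. Also open, on these data alone, is whether a ring carrying an amine or a carboxylic acid on this nitrogen, or a change elsewhere on the shared core, would bring the series down to a clearly lower number.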